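The source may hold more compounds than are shown below. What is called first, only, known or untested is meant among the compounds shown, and "the series" means these compounds.

In a functional assay on Jurkat cells for inhibition of nuclear factor NF-kappa-B complex (Homo sapiens) (a higher number here means a weaker inhibitor, a lower number a stronger inhibitor), compound 2 `CCOC(=O)c1cnc(-c2cnc3ccccc3c2)nc1NN1C(=O)C=C(C)C1=O` gives 6000 nM, the highest of the two numbers recorded so far. Among the measured compounds shown here, its nearest neighbour, compound 1 `CCOC(=O)c1cnc(-c2cc(Cl)nc(Cl)c2)nc1NN1C(=O)C=C(C)C1=O`, gives 2000 nM in this assay, and the single measured step, a 3.0-fold higher number from compound 1 to compound 2 (0.48 log units; beyond the scatter), separates the two; that step exchanged one aryl group for another on the same aromatic carbon of the shared core. Compound 3 `CCOC(=O)c1cnc(-c2cc3ccccc3s2)nc1NN1C(=O)C=C(C)C1=O` alters that same group once more: 1-benzothiophen-2-yl in place of quinolin-3-yl on an aromatic carbon. For the measured compounds named here, no measured pair shows this particular exchange, so the step from compound 1 to compound 2 is the only guide, and it indicates that swapping the aryl group at this carbon shifts this assay by a modest amount in either direction. For compound 3 the expected step is therefore a 1.5-fold lower number from compound 2 to compound 3 (0.18 log units; within the scatter), a modest change whose direction is uncertain. Compound 3 is estimated at 4000 nM, with a range from 1500 nM to 12000 nM.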

Compound 3, half-maximal inhibitory concentration: 4000 nM
Estimate against measurement, compound 3: no gap at the digits printed, and the stated range covers the measured number.
By their numbers in this assay, from the lowest: compounds 1, 3 and 2 (each within the scatter of the next, the first and the last beyond it).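

In this assay, 1-benzothiophen-2-yl, which brings a five-membered aromatic ring with sulfur to this carbon between two ring nitrogen atoms, leaves compound 3 within the scatter of both earlier compounds: a 1.5-fold lower number from compound 2 to compound 3 (0.18 log units; within the scatter), and a 2.0-fold higher number from compound 1 to compound 3 (0.30 log units; within the scatter). Among the compounds shown here, the earlier pair alone showed only a difference between two aryl groups, whereas compound 3 now sits within the scatter of each, so the only step beyond the scatter remains the one separating compound 1 and compound 2. Nothing measured here explains how these aryl groups relate to the numbers.

The compounds shown leave open whether this carbon would tolerate a non-aromatic group, such as a morpholine or a simple amine, in place of an aryl ring. They also leave open how a carboxylic acid or a primary amide in place of the ethoxycarbonyl group would read in this assay.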